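Compound 3 to compound 4: swapping the piperazine tail

The source may hold more compounds than are shown below. What is called first, only, known or untested is meant among the compounds shown, and "the series" means these compounds.

Values in a functional assay on LNCaP cells (Homo sapiens) for antiproliferative activity (on this read-out higher numbers stand for weaker inhibition and lower numbers for stronger inhibition), so far:
- compound 1 `CN1CCN(c2ccc(NC(=O)Nc3ccc(-c4nc(C5=CCOCC5)nc(N5C6CCC5COC6)n4)cc3)cc2)CC1` gives 25 nM
- compound 2 `CCN1CCN(c2ccc(NC(=O)Nc3ccc(-c4nc(C5CCOCC5)nc(N5C6CCC5COC6)n4)cc3)cc2)CC1` gives < 0.8 nM (a limit of the assay)
- compound 3 `CC(C)N1CCN(c2ccc(NC(=O)Nc3ccc(-c4nc(C5CCOCC5)nc(N5C6CCC5COC6)n4)cc3)cc2)CC1` gives 18 nM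

For the measured compounds named here, compound 3 (18 nM) lies within the scatter of compound 1 (25 nM), the only other exact number. Compound 2 stands at a limit (< 0.8 nM).

Compound 4 `CN(C)C1CCN(C(=O)c2ccc(NC(=O)Nc3ccc(-c4nc(C5CCOCC5)nc(N5C6CCC5COC6)n4)cc3)cc2)CC1` carries (4-(dimethylamino)piperidin-1-yl)carbonyl in place of 4-isopropylpiperazin-1-yl on an aromatic carbon, para to a large group. Going by the values given here, the only measured step on this substituent is an at least 22-fold higher number from compound 2 to compound 3 (1.35 log units; beyond the scatter) and it is large, so a small change at this end of the molecule can move the number far in this assay for this series. Among the compounds with values here, no measured step covers the entering group, which leaves the transfer uncertain. Compound 4 loses the isopropyl end that compound 3 gained in an at least 22-fold higher number from compound 2 to compound 3 (1.35 log units; beyond the scatter) and a move to a lower number is therefore expected. The expected step is a 4.5-fold lower number from compound 3 to compound 4 (0.65 log units; beyond the scatter) and it carries a wide margin. In this assay the estimate for compound 4 is 4 nM within an expected range of 0.8 nM to 20 nM for now.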

Compound 4, half-maximal inhibitory concentration: < 0.8 nM
Compound 4 ended at the assay's limit; the forecaster's own chance of this, stated with the estimate: 25%; middle value at least 5.0-fold (0.69 log units) from the limit.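

In this assay, the position on an aromatic carbon, para to a large group, accepts more than alkyl changes on a piperazine: (4-(dimethylamino)piperidin-1-yl)carbonyl in place of 4-isopropylpiperazin-1-yl gives an at least 22-fold lower number from compound 3 to compound 4 (1.35 log units; beyond the scatter). A piperazine at this position is therefore not required, and a group with a different ring and a carbonyl reaches the same end of the read-out as the 4-ethylpiperazin-1-yl of compound 2. Compound 2 and compound 4 both stand at a limit, so the step between them cannot be read: the limit of < 0.8 nM in this assay, at which 2 of the 4 values shown sit.

Going by these compounds, the swap changes the carbonyl, the ring and the dimethylamino group together, and the share of each in the step remains open. A 4-(dimethylamino)piperidin-1-yl without the carbonyl, or a morpholine amide at this position, would help separate them.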